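From Bromo to tert-Butyl: Expected Effect on Solubility

This account rests on a few compounds, and the source may have more. Where it says the series, first, only, none or still open, it means among the compounds named here.

Compound 2 `CC(C)(C)c1cc(C(=O)Nc2nc(CN)cs2)n(Cc2ccc(Br)cc2)n1` carries a 4-bromophenyl group on the saturated chain carbon bound to an aromatic nitrogen of the shared core. In a physicochemical assay for solubility, read by turbidimetry, measured as kinetic solubility, at pH 7.4 (a lower number here means a less soluble compound, a higher number a more soluble compound), compound 2 gives > 200 ug/mL, which is a limit of the assay rather than a number (the limit of > 200 ug/mL in this assay, at which 1 of the 2 values shown sits). Compound 1 `CC(C)(C)c1cc(C(=O)Nc2nc(CN)cs2)n(Cc2ccccc2Cl)n1` differs from compound 2 only in carrying 2-chlorophenyl at that place, and in this assay compound 1 gives 80 ug/mL. Within the data shown here, the single measured step, an at least 2.5-fold higher number from compound 1 to compound 2 (0.39 log units; beyond the scatter), therefore runs upward to the limit.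

Compound 3 `CC(C)(C)c1ccc(Cn2nc(C(C)(C)C)cc2C(=O)Nc2nc(CN)cs2)cc1` brings the next change: tert-butyl in place of bromo on an aromatic carbon. Among the measured compounds shown here, no measured step exchanges bromo for tert-butyl, so the measured step, which alters both the halogen and its position on the phenyl ring, bears on it only loosely, showing that a change on this ring can move this assay by at least a modest amount. With compound 2 sitting at a limit, the direction of the new step is not fixed by the data. A modest drop is expected, and the expected step is an at least 2.0-fold lower number from compound 2 to compound 3 (0.30 log units; that floor lies within the scatter). For compound 3 the estimate is 100 ug/mL, with a range from 30 ug/mL to 200 ug/mL.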

Compound 3, solubility: 10 ug/mL
The estimate for compound 3 lay 10-fold (1.00 log units) above the measured number; the whole stated range lies above it.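

In this assay, the change from 4-bromophenyl to 4-(tert-butyl)phenyl gives an at least 20-fold lower number from compound 2 to compound 3 (1.30 log units; beyond the scatter), so swapping one group at this single carbon of the ring can produce a large step, larger than the earlier step suggested. That size is only a floor, and the true gap could be wider, for compound 2 stands at a limit of the assay and not at a number: the limit of > 200 ug/mL in this assay, at which 1 of the 3 values shown sits. The comparison with the 2-chlorophenyl compound points the same way, with an 8.0-fold lower number from compound 1 to compound 3 (0.90 log units; beyond the scatter), so compound 3 reads lower than both halogen-bearing compounds, by a clear margin in each case.

On these data alone, what a methyl, a methoxy or an amine would give on the same carbon remains open, so three compounds cannot say whether this drop is particular to tert-butyl or would be shared by other carbon groups. Among these compounds, a 4-chlorophenyl group would also be informative, as the one step between the two halogen-bearing compounds changes both the halogen and its place on the ring, and these two changes remain unseparated.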